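Benzyl in place of propyl on the ring amine

A few compounds are considered here, and "the series" means these few. Any claim that something is new, unique, unknown or untested is made for them only; others in the source may bear on it.

Measured compounds:
compound 1, `CO[C@@]12CCN(C)C[C@H]1[C@H](c1ccccc1)C(C#N)=C(N)O2`, 19800 nM in a functional assay on trachea (Cavia porcellus); a lower number here means a stronger inhibitor, a higher number a weaker inhibitor
compound 2, `CCN1CC[C@@]2(OC)OC(N)=C(C#N)[C@@H](c3ccccc3)[C@@H]2C1`, 23400 nM in this assay
compound 3, `CCCN1CC[C@@]2(OC)OC(N)=C(C#N)[C@@H](c3ccccc3)[C@@H]2C1`, 20700 nM in this assay

The three measured compounds share one core and differ only in the chain on the ring amine nitrogen. Their numbers in this assay sit close together: a 1.0-fold higher number from compound 1 to compound 3 (0.02 log units; within the scatter) and a 1.1-fold lower number from compound 2 to compound 3 (0.05 log units; within the scatter), so compound 3 stands within the scatter of both neighbours, and lengthening the chain by one carbon at a time, as in a 1.2-fold higher number from compound 1 to compound 2 (0.07 log units; within the scatter), has not moved the read-out.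

Compound 4, `CO[C@@]12CCN(Cc3ccccc3)C[C@H]1[C@H](c1ccccc1)C(C#N)=C(N)O2`, carries the change (phenyl in place of ethyl on a saturated chain carbon bound to an amine nitrogen in a ring). The measured steps all swap small chains for slightly longer ones and all lie within the scatter; none of them places an aromatic ring in this position, so the data give no direct guide for a six-membered aromatic ring of carbon only entering here. With all three measured values so alike, the step of a 1.4-fold lower number from compound 3 to compound 4 (0.14 log units; within the scatter) is expected to be modest and uncertain in direction. Compound 4 is therefore estimated at 15000 nM, with a range from 4000 nM to 50000 nM.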

Compound 4, half-maximal inhibitory concentration: 22600 nM
Compound 4: middle estimate off by 1.5-fold (0.18 log units), on the low side; the measured number falls inside the stated range.
By their numbers in this assay, from the lowest: compounds 1, 3, 4 and 2 (each within the scatter of the next).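

For the compounds shown here, with benzyl in place of propyl on the ring amine, an aromatic ring stands at this place for the first time, and in this assay the result is a 1.1-fold higher number from compound 3 to compound 4 (0.04 log units; within the scatter). The comparisons with the two shorter chains read the same, at a 1.0-fold lower number from compound 2 to compound 4 (0.02 log units; within the scatter) and a 1.1-fold higher number from compound 1 to compound 4 (0.06 log units; within the scatter), so these four compounds cannot be told apart in this read-out, whether the group on the ring amine nitrogen carries a six-membered aromatic ring or only a short saturated chain. No measured evidence is available to explain this result.

The compounds shown leave open whether any other group here, such as a longer chain ending in phenyl or a chain bearing a carboxylic acid, would stand apart from these four. On these data alone, all four also share one core, so the effect of replacing its nitrile with an amide remains unknown.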